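A Smaller Aromatic Group at the Same Position

The source may report more compounds than this note shows. Statements on the series, on what has been measured and on what is new or still open speak of the compounds shown alone.

Compound 1 `Nc1nc2c(c(-c3ccccc3)cn2[C@@H]2O[C@H](CO)[C@@H](O)[C@H]2O)c(=O)[nH]1`: > 100000 nM in an ADME assay on MRC5 cells (Homo sapiens), read by MTT assay, with a stated time of 72 h (on this read-out higher numbers stand for weaker inhibition and lower numbers for stronger inhibition), a limit of this assay.
Compound 2 `Cc1ncnc2c1c(-c1cccs1)cn2[C@@H]1O[C@H](CO)[C@@H](O)[C@H]1O`: > 100000 nM in this assay, again a limit.
Compound 3 `O=c1[nH]cnc2c1c(-c1cc3ccccc3o1)cn2[C@@H]1O[C@H](CO)[C@@H](O)[C@H]1O`: > 100000 nM in this assay, also a limit.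

Compound 3 therefore stands at the limit of this assay rather than at a measured number, and the limit of > 100000 nM in this assay, at which 3 of the 3 values shown sit, shows that every value given here sits there as well. Compound 4 `O=c1[nH]cnc2c1c(-c1ccsc1)cn2[C@@H]1O[C@H](CO)[C@@H](O)[C@H]1O` differs from compound 3 by thiophen-3-yl in place of 1-benzofuran-2-yl on an aromatic carbon. Within the data shown here, with no measured step between these compounds to draw on, the step from compound 3 to compound 4 in this assay is expected to be none beyond the scatter, so that the estimated step that the limit leaves unreadable from compound 3 to compound 4 is essentially flat. Compound 4 is accordingly expected to give about 150000 nM, between 50000 nM and 500000 nM, most likely again reported only as a limit.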

Compound 4, half-maximal inhibitory concentration: > 100000 nM
Compound 4: no number, only a limit (the forecaster's own chance of this, stated with the estimate: 85%); the middle value lies beyond the limit too.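

Compound 3 and compound 4 both sit at a limit in this assay, so no step can be read between them: the limit of > 100000 nM in this assay, at which 4 of the 4 values shown sit. The compounds shown leave open what size of step thiophen-3-yl in place of 1-benzofuran-2-yl brings.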